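The compounds below may be only part of what the source reports. "The series", "measured", "known", "first", "only" and "open" are said of these compounds alone.

Measured so far:
compound 1 `COc1cc(N(C)CCN(C)C)c(NC(=O)c2ncccn2)cc1Nc1nccc(-c2cn(C)c3ccccc23)n1` — 2490 nM
compound 2 `COc1cc(N(C)C)c(NC(=O)c2ccccn2)cc1Nc1nccc(-c2cn(C)c3ccccc23)n1` — 8290 nM

In a functional assay on A549 cells (Homo sapiens) for antiproliferative activity, read by MTT assay, with a stated time of 72 h (on this read-out lower numbers stand for stronger inhibition and higher numbers for weaker inhibition), compound 2 gives the highest of the two numbers; compound 1 gives the lower value, and the gap between them lies beyond the scatter. The two differ in more than one place, so nothing can be said about the source of that gap.

Compound 3 `COc1cc(N(C)C)c(NC(=O)c2ncccn2)cc1Nc1nccc(-c2cn(C)c3ccccc23)n1` is not yet measured. It differs from compound 2 by one change only: pyrimidin-2-yl in place of pyridin-2-yl on a carbonyl carbon. For the measured compounds named here, no step of this kind between two measured compounds exists, so the size and direction of the effect are open. On the numbers that exist, compound 3 is expected to give a number similar to or somewhat lower than that of compound 2, with the step of a 1.8-fold lower number from compound 2 to compound 3 (0.27 log units; within the scatter) most likely near the edge of the scatter. The estimate for compound 3 is 4500 nM, with a range from 1500 nM to 13000 nM.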

Compound 3, half-maximal inhibitory concentration: 8640 nM
Beside the measured number, compound 3's estimate is 1.9-fold (0.28 log units) below it; measured number inside the range.
By their numbers in this assay, from the lowest: compound 1; then compounds 2 and 3 (each within the scatter of the next).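

In this assay, pyrimidin-2-yl in place of pyridin-2-yl on a carbonyl carbon gives a 1.0-fold higher number from compound 2 to compound 3 (0.02 log units; within the scatter), so this ring exchange leaves the read-out unchanged with the shorter side chain in place. For the compounds shown here, on the other side of the molecule, hydrogen in place of (dimethylamino)methyl on a saturated chain carbon bound to a nitrogen on an aromatic ring gives a 3.5-fold higher number from compound 1 to compound 3 (0.54 log units; beyond the scatter), a modest step and the first single change to go beyond the scatter. No measurement bears on the reason for either result.

From the compounds shown here alone, whether the ring exchange stays as silent with the (dimethylamino)methyl group present remains open. Also open, going by these compounds, are how a longer chain or a terminal morpholine would read at the chain position, and how a phenyl ring would read on the carbonyl carbon.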